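Moving a Chlorine Around the Aryl Ring of a Quinoline Acid

A few compounds are considered here, and "the series" means these few. Any claim that something is new, unique, unknown or untested is made for them only; others in the source may bear on it.

Measured so far:
compound 1, `O=C(O)CCCCCOc1cc(-c2ccc(Cl)cc2)c2ccccc2n1`, 30 nM in an assay on membranes from spleen (Cavia porcellus) for binding affinity to leukotriene B4 receptor 1 (Homo sapiens); on this read-out higher numbers stand for weaker inhibition and lower numbers for stronger inhibition
compound 2, `Cc1ccc(-c2cc(OCCCCC(C)(C)C(=O)O)nc3ccccc23)cc1`, 30 nM

Both compounds share a core carrying an aryl group and an acid-tipped chain. In this assay compound 1 gives 30 nM, and compound 2 gives 30 nM, so compound 2 stands level with compound 1 within the usual scatter of this assay. Because the two differ in more than one place, nothing can be said about which of their differences matters.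

Compound 3, `CC(C)(CCCCOc1cc(-c2cccc(Cl)c2)c2ccccc2n1)C(=O)O`, keeps the branched acid chain of compound 2 and changes only the aryl group: 3-chlorophenyl in place of 4-methylphenyl on an aromatic carbon. Going by the values given here, no measured pair shows what moving a chlorine on this ring does, so the expectation rests on compound 1 and compound 2 alone. A modest weakening, possibly none beyond the scatter, is estimated as the step of a 2.0-fold higher number from compound 2 to compound 3 (0.30 log units; within the scatter). For compound 3 the estimated value in this assay is 60 nM, expected to lie between 15 nM and 250 nM.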

Compound 3, half-maximal inhibitory concentration: 1100 nM
Beside the measured number, compound 3's estimate is 18-fold (1.26 log units) below it, and the stated range ends below it.
By their numbers in this assay, from the lowest: compounds 1 and 2 (each within the scatter of the next); then compound 3.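

With the branched acid chain held fixed, replacing 4-methylphenyl with 3-chlorophenyl on this aromatic carbon gives, in this assay, a 37-fold higher number from compound 2 to compound 3 (1.56 log units; beyond the scatter). Going by these compounds alone, this is the first change at a single place, and it shows that the aryl group here strongly affects the measured value, which the earlier pair, differing in more than one place, could not reveal. The two groups have the same heavy-atom count, one aromatic carbon ring, no hydrogen-bond donors or acceptors and no net charge, yet they are far from interchangeable, and nothing measured here explains the gap.

This single swap changes both the atom on the aryl ring and its place, so the two effects remain tangled. A 3-methylphenyl group on the same chain would separate them by keeping the methyl and changing only its place.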